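Removing the Methoxy Group from a Nitrile Sulfone Analogue

A few compounds are considered here, and "the series" means these few. Any claim that something is new, unique, unknown or untested is made for them only; others in the source may bear on it.

Measured compounds:
compound 1 `CC(=O)/C(=C\c1c(-c2ccccc2)[nH]c2ccccc12)S(=O)(=O)c1ccccc1` — 2000 nM
compound 2 `O=C(/C(=C\c1c(-c2ccccc2)[nH]c2ccccc12)S(=O)(=O)c1ccccc1)c1ccccc1` — "not determined" (no result reported)
compound 3 `COc1ccc2[nH]c(-c3ccccc3)c(/C=C(\C#N)S(=O)(=O)c3ccccc3)c2c1` — 9300 nM

In a functional assay on A498 cells (Homo sapiens) for inhibition, read by sulforhodamine B assay, with a stated time of 48 h (a lower number here means a stronger inhibitor of growth, a higher number a weaker inhibitor of growth), compound 1 gives 2000 nM. In this assay compound 2 gives "not determined" (no result reported); it carries a benzoyl in place of the acetyl of compound 1. Compound 3 gives 9300 nM, the highest of the two numbers; compound 1 stands nearest, with a lower number, and the gap between them lies beyond the usual scatter.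

Compound 4 `N#C/C(=C\c1c(-c2ccccc2)[nH]c2ccccc12)S(=O)(=O)c1ccccc1` differs from compound 3 in one place: hydrogen in place of methoxy on an aromatic carbon. Among the compounds with values here, no measured pair shows this change on its own. Within the data shown here, compound 1 also lacks the methoxy and gives a lower number than compound 3, but it differs from compound 4 in the acetyl against the nitrile as well, so the two values show only that the unsubstituted core can reach the lower number.

The expected step of a 2.1-fold lower number from compound 3 to compound 4 (0.32 log units; beyond the scatter) is toward a lower number, and it may fall within the scatter. Compound 4 is therefore estimated at 4500 nM in this assay, with a range from 1500 nM to 12000 nM.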

Compound 4, concentration for 50% growth inhibition: 11000 nM
Estimate against measurement, compound 4: 2.4-fold (0.39 log units) below; measured number inside the range.
By their numbers in this assay, from the lowest: compound 1; then compounds 3 and 4 (each within the scatter of the next).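

In this assay, within the data shown here, hydrogen in place of methoxy on this aromatic carbon, with the nitrile kept, gives a 1.2-fold higher number from compound 3 to compound 4 (0.07 log units; within the scatter), so this change alone leaves the number within the scatter, something no earlier pair could show. The lower number of compound 1 therefore does not follow from the missing methoxy, since with that group absent from both compounds, cyano in place of acetyl on the double-bonded chain carbon gives a 5.5-fold higher number from compound 1 to compound 4 (0.74 log units; beyond the scatter), a step beyond the scatter that places the difference at the chain rather than on the aromatic ring. Nothing measured here accounts for either step.

On these data alone, whether methoxy and hydrogen also stand level when acetyl rather than nitrile sits on the chain remains open, as does whether an amine or a hydroxyl on the same aromatic carbon would leave the number unchanged. The compounds shown also leave open how far the chain position tolerates other groups, such as a carboxylic acid or a longer chain ketone in place of the acetyl.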